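The source may report more compounds than this note shows. Statements on the series, on what has been measured and on what is new or still open speak of the compounds shown alone.

Compound 2, with the structure `O=c1nc(NC2CCCCC2)oc2c([N+](=O)[O-])cc(C(F)(F)F)cc12`, gives 5.39 ug/mL in an ADME assay on Vero cells (Chlorocebus sabaeus) for cytotoxicity, read by MTT assay, with a stated time of 48 h (a higher number here means a weaker inhibitor, a lower number a stronger inhibitor), and is the only compound in this set for which a number rather than a limit is shown. Compound 1, the structure `O=c1nc(NCc2ccc(F)cc2)oc2c([N+](=O)[O-])cc(C(F)(F)F)cc12`, gives only a limit, > 64 ug/mL. Compound 3, the structure `O=c1cc(Nc2ccccc2)sc2c([N+](=O)[O-])cc(C(F)(F)F)cc12`, likewise gives only a limit, > 64 ug/mL. The one step that can be sized is an at least 11-fold lower number from compound 1 to compound 2 (1.07 log units; beyond the scatter), and it rests on (the limit of > 64 ug/mL in this assay, at which 2 of the 3 values shown sit), so its true size may be larger than shown.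

Compound 4, the structure `CN(Cc1ccccc1)c1nc(=O)c2cc(C(F)(F)F)cc([N+](=O)[O-])c2o1`, has not yet been measured. It differs from compound 2 by benzyl(methyl)amino in place of cyclohexylamino on an aromatic carbon.

The change partly retraces the step from compound 1 to compound 2: a benzyl-type group on the nitrogen returns, though now with a methyl on that nitrogen, while the cyclohexyl leaves. Going by the values given here, the only relevant measured step, an at least 11-fold lower number from compound 1 to compound 2 (1.07 log units; beyond the scatter), was large, so an upward step of comparable scale is expected in this assay for compound 4, estimated at a 5.6-fold higher number from compound 2 to compound 4 (0.75 log units; beyond the scatter). Compound 4 is therefore expected to give about 30 ug/mL, within a range from 8 ug/mL to 100 ug/mL.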

Compound 4, half-maximal inhibitory concentration: 3.84 ug/mL
The estimate for compound 4 lay 7.8-fold (0.89 log units) above the measured number; the whole stated range lies above it.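

In this assay, benzyl(methyl)amino in place of cyclohexylamino gives a 1.4-fold lower number from compound 2 to compound 4 (0.15 log units; within the scatter) at this position, so the two groups cannot be told apart here, and a benzyl-type group on this nitrogen does not by itself go with a high number. The other new step, an at least 16-fold lower number from compound 1 to compound 4 (1.22 log units; beyond the scatter) for benzyl(methyl)amino in place of (4-fluorobenzyl)amino, shows that a low number is not tied to the cyclohexyl ring and that compounds with benzyl-type groups can differ widely. The true size of that step remains unknown, as it rests on a limit: the limit of > 64 ug/mL in this assay, at which 2 of the 4 values shown sit.

Because the fluorine and the methyl differ together between compound 1 and compound 4, the compounds shown do not say which of them matters. A plain benzylamino or a cyclohexyl(methyl)amino group would bear on that question.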